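Swapping the piperidine acyl group: pivaloyl to benzyloxycarbonyl

This account rests on a few compounds, and the source may have more. Where it says the series, first, only, none or still open, it means among the compounds named here.

Of the compounds shown here, three sharing one core have been measured in an ADME assay on Caco-2 cells (Homo sapiens) for permeability, in the apical to basolateral direction; on this read-out higher numbers stand for higher permeability and lower numbers for lower permeability. Compound 1 `Cn1cncc1CN1CC(N(CCn2cccc2)S(=O)(=O)c2ccccn2)Cc2cc(C#N)ccc21` gives 12.4 10^-6 cm/s, compound 2 `Cn1cncc1CN1CC(N(CC2CCN(C(=O)C(C)(C)C)CC2)S(=O)(=O)c2ccccn2)Cc2cc(C#N)ccc21` gives 0.5 10^-6 cm/s, and compound 3 `Cn1cncc1CN1CC(N(Cc2ccc(S(C)(=O)=O)cc2)S(=O)(=O)c2ccccn2)Cc2cc(C#N)ccc21` gives 0.2 10^-6 cm/s. Compound 2 therefore stands second highest of the three numbers: its nearest neighbour is compound 3, reached by a 2.5-fold lower number from compound 2 to compound 3 (0.40 log units; beyond the scatter), and its furthest is compound 1, from which it is reached by a 25-fold lower number from compound 1 to compound 2 (1.39 log units; beyond the scatter).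

Compound 4 `Cn1cncc1CN1CC(N(CC2CCN(C(=O)OCc3ccccc3)CC2)S(=O)(=O)c2ccccn2)Cc2cc(C#N)ccc21` differs from compound 2 in a single place: benzyloxy in place of tert-butyl on a carbonyl carbon. Among the compounds with values here, every measured step so far varies the group on the saturated chain carbon bound to the sulfonamide nitrogen, as in a 62-fold lower number from compound 1 to compound 3 (1.79 log units; beyond the scatter); none touches the carbonyl carbon where compound 4 differs, so no measured step bears directly on this change. The three values show that this region of the molecule can move this assay a great deal, but they give no direction for the change at hand.

With nothing to point up or down, compound 4 is expected to stay close to compound 2, a step of a 1.2-fold higher number from compound 2 to compound 4 (0.08 log units; within the scatter) in this assay. Compound 4 is estimated at 0.6 10^-6 cm/s, with a range from 0.25 10^-6 cm/s to 1.5 10^-6 cm/s.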

Compound 4, apparent permeability: 1 10^-6 cm/s
The estimate for compound 4 lay 1.7-fold (0.22 log units) below the measured number, within the range that was stated.
By their numbers in this assay, from the lowest: compound 3; then compounds 2 and 4 (each within the scatter of the next); then compound 1.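

In this assay, within the data shown here, the only measured change on the carbonyl carbon, benzyloxy in place of tert-butyl, comes out as a 2.0-fold higher number from compound 2 to compound 4 (0.30 log units; within the scatter) and so leaves the two compounds indistinguishable on this read-out. The entering group brings a six-membered aromatic ring and a hydrogen-bond acceptor that tert-butyl does not have, yet the step is still within the scatter. Among these compounds, the large steps seen earlier, such as a 25-fold lower number from compound 1 to compound 2 (1.39 log units; beyond the scatter), replace the whole group on the saturated chain carbon, whereas this exchange at the far end of the acyl group gives no step of that kind. Nothing in the data shown accounts for this result.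

Going by these compounds, it remains open whether a different group on this carbonyl carbon, such as an amine or a methoxy group, would move the number beyond the scatter. Also open, on these data alone, is whether a piperidine nitrogen carrying a plain methyl group instead of any carbonyl would come closer to compound 1 with its 12.4 10^-6 cm/s in this assay.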